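A few compounds are considered here, and "the series" means these few. Any claim that something is new, unique, unknown or untested is made for them only; others in the source may bear on it.

Measured in a physicochemical assay for solubility, in phosphate buffer, at pH 7.4; a lower number here means a less soluble compound, a higher number a more soluble compound:
- compound 1 `CC(=O)N[C@@H]1CCC[C@H](C(=O)Nc2cc(-c3cnc4ccccn34)c(Cl)cn2)C1`: 120000 nM
- compound 2 `CC(=O)N[C@@H]1CCC[C@H](C(=O)Nc2cc(-c3cnn4c3COCC4)c(Cl)cn2)C1`: 220000 nM
- compound 3 `CC(=O)N[C@@H]1CCC[C@H](C(=O)Nc2cc(-c3cnn4c3CC(C)(C)C4)c(Cl)cn2)C1`: 150000 nM

Compound 3 stands level with the other two compounds, as a 1.3-fold higher number from compound 1 to compound 3 (0.10 log units; within the scatter) and a 1.5-fold lower number from compound 2 to compound 3 (0.17 log units; within the scatter) show. Compound 4 `CC1(C)Cc2c(-c3cc(NC(=O)[C@H]4C[C@@H](O)C4)ncc3Cl)cnn2C1` differs from it by 3-hydroxycyclobutyl in place of 3-acetamidocyclohexyl on a carbonyl carbon, with 3-hydroxycyclobutyl in place of 3-acetamidocyclohexyl on a carbonyl carbon. For the measured compounds named here, no measured step touches this place. All three exchange a group on an aromatic carbon, including a 1.8-fold higher number from compound 1 to compound 2 (0.26 log units; within the scatter), so they give only indirect guidance. No step beyond the scatter is therefore expected in this assay, though with wide uncertainty. The expected step is a 1.1-fold higher number from compound 3 to compound 4 (0.05 log units; within the scatter). For compound 4 the estimated value is 170000 nM, with an expected range of 60000 nM to 400000 nM.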

Compound 4, solubility: 15000 nM
For compound 4 the middle estimate is 11-fold (1.05 log units) above the measured one, outside the stated range (below it).
By their numbers in this assay, from the lowest: compound 4; then compounds 1, 3 and 2 (each within the scatter of the next).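

For the compounds shown here, the place on the carbonyl carbon, which no earlier step touched, proves able to move the number in this assay: 3-hydroxycyclobutyl in place of 3-acetamidocyclohexyl gives a 10-fold lower number from compound 3 to compound 4 (1.00 log units; beyond the scatter) and so lies beyond the scatter. The earlier exchanges on the aromatic carbon all stayed within it, so they did not foreshadow a step of this size. No measurement at hand accounts for this step. Ring and substituent change together here, so the compounds shown leave open which of the two carries the step. They also leave open how an amine or a carboxylic acid in place of the hydroxyl on the cyclobutyl ring would read.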